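The source may report more compounds than this note shows. Statements on the series, on what has been measured and on what is new or still open speak of the compounds shown alone.

In a functional assay on MCF7 cells (Homo sapiens) for antiproliferative activity, read by MTT assay, with a stated time of 72 h (a higher number here means a weaker inhibitor, a lower number a stronger inhibitor), compound 1 `CCN(CC)CCNC(=O)c1cc(C(CC)(CC)c2ccc(C#CC(O)(CC)CC)c(C)c2)cn1CC` gives 1800 nM, compound 2 `CCn1cc(C(CC)(CC)c2ccc(C#CC(O)(CC)CC)c(C)c2)cc1C(=O)NCCN(C)C` gives 13400 nM and compound 3 `CCn1cc(C(CC)(CC)c2ccc(C#CC(O)(CC)CC)c(C)c2)cc1C(=O)NCCCN(C)C` gives 20200 nM. Compound 3 therefore stands level with compound 2 within the scatter, and both are weaker than compound 1. The measured steps are a 7.4-fold higher number from compound 1 to compound 2 (0.87 log units; beyond the scatter), an 11-fold higher number from compound 1 to compound 3 (1.05 log units; beyond the scatter) and a 1.5-fold higher number from compound 2 to compound 3 (0.18 log units; within the scatter). Compound 4 `CCn1cc(C(CC)(CC)c2ccc(C#CC(O)(CC)CC)c(C)c2)cc1C(=O)OCCO` has 2-hydroxyethoxy in place of (3-(dimethylamino)propyl)amino on a carbonyl carbon. The measured steps only alter the amine end of the chain, so none tests this exchange directly and they offer only a rough guide to size. The expected step in this assay is modest and towards a lower number, a 2.5-fold lower number from compound 3 to compound 4 (0.40 log units; beyond the scatter). For compound 4 the estimate is 8000 nM, with an expected range of 1500 nM to 30000 nM.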

Compound 4, half-maximal inhibitory concentration: 1880 nM
The estimate for compound 4 lay 4.3-fold (0.63 log units) above the measured number; low and high end bracket the measured number.
By their numbers in this assay, from the lowest: compounds 1 and 4 (each within the scatter of the next); then compounds 2 and 3 (each within the scatter of the next).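

In this assay and with no amine left in the chain, 2-hydroxyethoxy on the carbonyl carbon gives an 11-fold lower number from compound 3 to compound 4 (1.03 log units; beyond the scatter) and a 7.1-fold lower number from compound 2 to compound 4 (0.85 log units; beyond the scatter) against the two dimethylamino amides. Against the diethylamino amide it gives a 1.0-fold higher number from compound 1 to compound 4 (0.02 log units; within the scatter) and so lies within the scatter, showing that this position needs no terminal amine to reach that level. Nothing measured here explains these steps. Still open, on these data alone, is how a 2-hydroxyethyl amide, a plain ethyl ester or a carboxylic acid would read on this carbonyl carbon, and thus whether the ester oxygen or the terminal hydroxyl matters.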